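From ethylsulfonyl to phenylcarbamoyl on the ring amine

The source may hold more compounds than are shown below. What is called first, only, known or untested is meant among the compounds shown, and "the series" means these compounds.

Compound 1 `C=CS(=O)(=O)N1CCN(c2ncnc3sc(-c4ccccc4)cc23)CC1`: 54200 nM
Compound 2 `C=CS(=O)(=O)N1CCN(c2ncnc3sc(-c4ccc(OC)nc4)cc23)CC1`: 9270 nM
Compound 3 `CCS(=O)(=O)N1CCN(c2ncnc3sc(-c4ccc(N5CCN(C)CC5)cc4)cc23)CC1`: 7330 nM

In a functional assay on MDA-MB-231 cells (Homo sapiens) for antiproliferative activity, read by MTT assay, with a stated time of 48 h (on this read-out lower numbers stand for stronger inhibition and higher numbers for weaker inhibition), compound 3 gives 7330 nM and cannot be told apart from compound 2 at 9270 nM on these numbers, while compound 1 stands clearly higher at 54200 nM on the same scale.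

Compound 4 `CN1CCN(c2ccc(-c3cc4c(N5CCN(C(=O)Nc6ccccc6)CC5)ncnc4s3)cc2)CC1` differs from compound 3 in one place, with phenylcarbamoyl in place of ethylsulfonyl on an amine nitrogen in a ring and the rest of the molecule unchanged.

Among the measured compounds shown here, the only measured step at a single place is a 5.8-fold lower number from compound 1 to compound 2 (0.77 log units; beyond the scatter) for 6-methoxypyridin-3-yl in place of phenyl on an aromatic carbon. That modest step lies at another place on the molecule and does not speak directly to this exchange. For the measured compounds named here, no pair of measured compounds isolates a change on the ring amine nitrogen. From the compounds shown here alone, with no direct evidence, no step beyond the scatter is expected in this assay and the direction remains open. The estimated step is a 1.2-fold lower number from compound 3 to compound 4 (0.09 log units; within the scatter) and it is a cautious expectation only. Compound 4 is expected at 6000 nM with an estimated range from 1800 nM to 20000 nM in this assay when it is measured.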

Compound 4, half-maximal inhibitory concentration: 7590 nM
For compound 4 the middle estimate is 1.3-fold (0.10 log units) below the measured one, within the range that was stated.
By their numbers in this assay, from the lowest: compounds 3, 4 and 2 (each within the scatter of the next); then compound 1.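

Among the compounds shown here, the exchange on the amine nitrogen of the six-membered non-aromatic ring with 2 nitrogen is the only change at this position that a measured pair isolates. In this assay the step is a 1.0-fold higher number from compound 3 to compound 4 (0.02 log units; within the scatter), so ethylsulfonyl and phenylcarbamoyl cannot be told apart on this read-out. The entering group has 9 heavy atoms against 5 and brings one six-membered aromatic ring of carbon only and 1 hydrogen-bond donor, yet with the rest of the molecule unchanged this exchange produces no step beyond the scatter, and nothing at hand explains why the two groups read alike.

From the compounds shown here alone, this is a single exchange on a single background, so it remains open whether the same result would hold with 6-methoxypyridin-3-yl on the aromatic carbon of the shared core. Going by these compounds, it also remains open how this nitrogen would read with a free ring amine, an acetyl group, or a longer chain ending in a carboxylic acid.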